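From methoxy to difluoromethoxy on compound 3

The source may hold more compounds than are shown below. What is called first, only, known or untested is meant among the compounds shown, and "the series" means these compounds.

Measured in a physicochemical assay for solubility, in phosphate buffer, with a stated time of 24 h, at pH 7.4; on this read-out lower numbers stand for lower solubility and higher numbers for higher solubility:
compound 1 `COc1ccc(-c2ccc(OCc3cc(C(=O)NS(=O)(=O)c4ccccc4)oc3C)cc2)c(C)c1`: 20 ug/mL
compound 2 `Cc1oc(C(=O)NS(=O)(=O)c2ccccc2)cc1COc1ccc(-c2ccccc2)cc1`: 2 ug/mL
compound 3 `COc1ccc(-c2ccc(OCc3cc(C(=O)NS(=O)(=O)c4ccccc4)oc3C)cc2)cc1`: 11 ug/mL

Compound 3 stands at 11 ug/mL, within the scatter of compound 1 and separated from compound 2 by a 5.5-fold higher number from compound 2 to compound 3 (0.74 log units; beyond the scatter). Compound 4 `Cc1oc(C(=O)NS(=O)(=O)c2ccccc2)cc1COc1ccc(-c2ccc(OC(F)F)cc2)cc1` carries one change, difluoromethyl in place of methyl on an oxygen on an aromatic ring. Going by the values given here, no measured step alters this group directly. The nearest evidence is a 5.5-fold higher number from compound 2 to compound 3 (0.74 log units; beyond the scatter), where methoxy replaced hydrogen, and a 1.8-fold lower number from compound 1 to compound 3 (0.26 log units; within the scatter) concerns a methyl elsewhere. Compound 4 keeps the oxygen, so no large step is expected. The expected step is a 1.4-fold lower number from compound 3 to compound 4 (0.14 log units; within the scatter), which would lie within the scatter. For compound 4 the estimated value is 8 ug/mL, with an expected range of 3 ug/mL to 20 ug/mL.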

Compound 4, solubility: < 0.6 ug/mL
Compound 4 ended at the assay's limit; the forecaster's own chance of this, stated with the estimate: 2%; middle value at least 13-fold (1.12 log units) from the limit.
By their numbers in this assay, from the lowest: compound 2; then compounds 3 and 1 (each within the scatter of the next). At a limit, below all of these: compound 4.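

In this assay compound 4 sits at a limit, which is not a number: the limit of < 0.6 ug/mL in this assay, at which 1 of the 4 values shown sits. Keeping the oxygen did not keep the read-out, as difluoromethyl in place of methyl gives an at least 18-fold lower number from compound 3 to compound 4 (1.26 log units; beyond the scatter). Where methoxy in place of hydrogen raised the number, difluoromethoxy in place of hydrogen gives an at least 3.3-fold lower number from compound 2 to compound 4 (0.52 log units; beyond the scatter), and replacing the 4-methoxy-2-methylphenyl group gives an at least 33-fold lower number from compound 1 to compound 4 (1.52 log units; beyond the scatter).

The compounds shown leave open how far under its limit compound 4 lies. They also leave open whether a trifluoromethoxy or ethoxy group on this ring would follow methoxy or difluoromethoxy.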